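Shortening the linker to the hydantoin in a pyridone series

The compounds below may be only part of what the source reports. "The series", "measured", "known", "first", "only" and "open" are said of these compounds alone.

Compound 1, `CC(C)C(CC1C(=O)NC(=O)N1C)c1ccc(-c2ccc3cccc(F)c3c2)[nH]c1=O`, was measured in a physicochemical assay for solubility, in phosphate buffer, measured as kinetic solubility (a higher number here means a more soluble compound, a lower number a less soluble compound), and gave 33600 nM. Compound 2, `CCn1ncc2c(F)cc(-c3ccc(C(/C=C4\OC(=O)NC4=O)(CC)CC)c(=O)[nH]3)cc21`, gave 30800 nM in this assay, and the two numbers lie within the usual scatter of each other, so neither compound can be set apart from the other on solubility. Compound 3, `CC(C)C(c1ccc(-c2ccc3cccc(F)c3c2)[nH]c1=O)C1C(=O)NC(=O)N1C`, has not yet been measured. It differs from compound 1 in one place: 3-methyl-2,5-dioxoimidazolidin-4-yl in place of (3-methyl-2,5-dioxoimidazolidin-4-yl)methyl on a saturated chain carbon bound to an aromatic carbon and a saturated chain carbon. Among the measured compounds shown here, the change removes one chain carbon between the core and the ring, and no measured pair here shows what such a shortening does to solubility. The account therefore expects no step beyond the scatter in this assay, perhaps a small gain, so that the estimated step from compound 1 to compound 3 is a 1.2-fold higher number from compound 1 to compound 3 (0.08 log units; within the scatter). Compound 3 is thus expected to give about 40000 nM, with a likely range from 15000 nM to 100000 nM.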

Compound 3, solubility: 17900 nM
Compound 3: middle estimate off by 2.2-fold (0.35 log units), on the high side, within the range that was stated.
By their numbers in this assay, from the lowest: compounds 3, 2 and 1 (each within the scatter of the next).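

Among the compounds shown here, the pair from compound 1 to compound 3 gives the first reading at this position: in this assay, 3-methyl-2,5-dioxoimidazolidin-4-yl in place of (3-methyl-2,5-dioxoimidazolidin-4-yl)methyl gives a 1.9-fold lower number from compound 1 to compound 3 (0.27 log units; within the scatter). Removing this one chain carbon therefore does not set compound 3 apart from compound 1 on solubility, so the group can be attached by either link without a step beyond the scatter. No measurement at hand bears on why the step has this size.

On these data alone, it remains open whether a longer chain at this place, or an amine or a carboxylic acid in place of the 3-methyl-2,5-dioxoimidazolidin-4-yl group, would give a step beyond the scatter in this assay. Also open, as far as these compounds go, is whether the same shortening would read alike on the core of compound 2.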